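A few compounds are considered here, and "the series" means these few. Any claim that something is new, unique, unknown or untested is made for them only; others in the source may bear on it.

In an assay (strain Wistar) for inhibition of Amine oxidase [flavin-containing] A (Rattus norvegicus) (on this read-out higher numbers stand for weaker inhibition and lower numbers for stronger inhibition), compound 1 `NC(=O)[C@@H]1CCCN1Cc1cc(=O)oc2cc(OCc3ccccc3)ccc12` gives 35000 nM. Compound 3 `CN(C)C(=O)Cc1cc(=O)oc2cc(OCc3ccccc3)ccc12` carries dimethylcarbamoyl where compound 1 carries 2-carbamoylpyrrolidin-1-yl. In this assay compound 3 gives 23100 nM, so that a 1.5-fold lower number from compound 1 to compound 3 (0.18 log units; within the scatter). Compound 2 `NC(=O)[C@@H]1CCCN1Cc1cc(=O)oc2cc(OCc3cccc(F)c3)ccc12`, with fluoro in place of hydrogen on an aromatic carbon, gives only > 100000 nM, which is a limit of this assay rather than a measured number. Accordingly an at least 2.8-fold higher number from compound 1 to compound 2 (0.45 log units; beyond the scatter). On the numbers shown, compound 2 therefore stands at the limit of > 100000 nM in this assay, at which 1 of the 3 values shown sits, and its true value is not known. Compound 4 `CN(C)Cc1cc(=O)oc2cc(OCc3cccc(F)c3)ccc12` is compound 2 with dimethylamino in place of 2-carbamoylpyrrolidin-1-yl on a saturated chain carbon bound to an aromatic carbon. Within the data shown here, the one measured step that resembles this change, a 1.5-fold lower number from compound 1 to compound 3 (0.18 log units; within the scatter), removed the same 2-carbamoylpyrrolidin-1-yl group and stayed within the scatter, although it entered dimethylcarbamoyl rather than dimethylamino. The step that the limit leaves unreadable from compound 2 to compound 4 is therefore expected to lie within the scatter. For compound 4 the estimate is 120000 nM, between 40000 nM and 400000 nM, and it is expected that this assay may again return only a limit.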

Compound 4, half-maximal inhibitory concentration: > 100000 nM
Compound 4 was reported as a limit; the forecaster's own chance of this, stated with the estimate: 60%; the middle value does not contradict the limit.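

Among these compounds, compound 2 and compound 4 are each reported only as a limit, not as a number, so no step between them can be read: the limit of > 100000 nM in this assay, at which 2 of the 4 values shown sit. The compounds shown leave open whether dimethylamino in place of 2-carbamoylpyrrolidin-1-yl changes the inhibition at all.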